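Benzamide terminus: cyano to propyl on the amide aryl

A few compounds are considered here, and "the series" means these few. Any claim that something is new, unique, unknown or untested is made for them only; others in the source may bear on it.

Compound 2 `N#Cc1ccc(C(=O)Nc2cccc(-c3oc4cc(-c5ccc(F)cc5)ccc4c(=O)c3O)c2)cc1` carries a 4-cyanophenyl on the carbonyl carbon of the amide; in a functional assay on HepG2 cells (Homo sapiens) for antiproliferative activity, read by CCK-8 assay, with a stated time of 72 h (on this read-out lower numbers stand for stronger inhibition and higher numbers for weaker inhibition), compound 2 gives 7110 nM. Within the data shown here, of the two numbers so far this is the lower one, yet its only neighbour, compound 1 `Cc1cccc(C(=O)Nc2cccc(-c3oc4cc(-c5ccc(F)cc5)ccc4c(=O)c3O)c2)c1` with a 3-methylphenyl on the carbonyl carbon, gives in this assay 13500 nM, and the step of a 1.9-fold lower number from compound 1 to compound 2 (0.28 log units; within the scatter) stays inside the scatter, so compound 2 cannot be called the more active of the pair.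

Compound 3 `CCCc1ccc(C(=O)Nc2cccc(-c3oc4cc(-c5ccc(F)cc5)ccc4c(=O)c3O)c2)cc1` differs from compound 2 in one place: propyl in place of cyano on an aromatic carbon, para to a large group. Among the measured compounds shown here, no measured step exchanges these two groups directly. For the measured compounds named here, the single step in hand, the 3-methylphenyl to 4-cyanophenyl exchange, shows that altering the substituent on this ring left the number inside the scatter. On that basis no step beyond the scatter is expected for compound 3, in either direction, as a 1.1-fold higher number from compound 2 to compound 3 (0.05 log units; within the scatter). Compound 3 is estimated at 8000 nM, with a range from 3000 nM to 25000 nM.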

Compound 3, half-maximal inhibitory concentration: 51500 nM
Compound 3: the middle estimate sits 6.4-fold (0.81 log units) below what was measured; the measured number lies above the stated range.
By their numbers in this assay, from the lowest: compounds 2 and 1 (each within the scatter of the next); then compound 3.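

In this assay, among these compounds, the substituent on the amide aryl ring now makes a readable difference: propyl in place of cyano on an aromatic carbon, para to a large group, gives the first step to leave the scatter (a 7.2-fold higher number from compound 2 to compound 3 (0.86 log units; beyond the scatter)). The exchange of 3-methylphenyl for 4-propylphenyl also leaves the scatter (a 3.8-fold higher number from compound 1 to compound 3 (0.58 log units; beyond the scatter)), so compound 3 stands apart from both neighbours, while compound 1 and compound 2 remain within the scatter of each other and the ring is shown to tolerate some groups better than others. No measurement at hand accounts for the weaker antiproliferative reading of compound 3.

On these data alone, it remains open whether the higher number follows the propyl chain itself or the departure of the nitrile, and an ethyl or a butyl on the same carbon would show whether the number tracks chain length. A 4-methylphenyl would separate the group from its place on the ring, and a terminal amine or carboxylic acid would test whether the trend holds beyond simple carbon chains.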